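Tetrahydropyran series: cyclohexyl to butenyl at the oxygen-flanked carbon

The source may hold more compounds than are shown below. What is called first, only, known or untested is meant among the compounds shown, and "the series" means these compounds.

Measured so far in a functional assay on A2780 cells (Homo sapiens) for antiproliferative activity; on this read-out higher numbers stand for weaker inhibition of growth and lower numbers for stronger inhibition of growth:
compound 1 `C[C@H]1CC(Cl)=C([Si](C)(C)C)[C@@H](C2CCCCC2)O1` gives 32000 nM
compound 2 `C[Si](C)(C)C1=C(Cl)C[C@H](Cc2ccccc2)O[C@@H]1CCCCCCCCCC1C=C(Cl)CCO1` gives 47000 nM
compound 3 `C[C@@H]1O[C@H](C2CCCCC2)C([Si](C)(C)C)=C(Cl)[C@H]1C` gives 38000 nM

All three numbers lie within the usual scatter of one another, so compound 3 is not separated from compound 1 or compound 2 beyond the scatter, and none of the three can be called stronger or weaker on this read-out. For the measured compounds named here, the only step between compounds that differ in one place, a 1.2-fold higher number from compound 1 to compound 3 (0.07 log units; within the scatter), is a methyl in place of hydrogen on a saturated ring carbon and stays within the scatter.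

Compound 4 `C=CCC[C@H]1O[C@@H](C)[C@H](C)C(Cl)=C1[Si](C)(C)C` differs from compound 3 by but-3-en-1-yl in place of cyclohexyl on a saturated ring carbon. Going by the values given here, no measured pair tests this kind of change; the one step known, from compound 1 to compound 3, concerns a different position and a different group, and the three values together show the series sitting in a narrow band. Nothing in the data therefore points to a step beyond the scatter in this assay, in either direction, though the change is larger than any tested here and the expectation is correspondingly loose. Compound 4 is estimated at 40000 nM, within 15000 nM to 100000 nM, which means an expected step of a 1.1-fold higher number from compound 3 to compound 4 (0.02 log units; within the scatter).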

Compound 4, concentration for total growth inhibition: 36000 nM
Estimate against measurement, compound 4: 1.1-fold (0.05 log units) above, and the stated range covers the measured number.
By their numbers in this assay, from the lowest: compounds 1, 4, 3 and 2 (each within the scatter of the next).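

In this assay the exchange of cyclohexyl for but-3-en-1-yl on the saturated ring carbon next to the ring oxygen stays within the scatter (a 1.1-fold lower number from compound 3 to compound 4 (0.02 log units; within the scatter)). The earlier step concerned only a methyl in place of hydrogen at a different ring carbon, whereas this one shows that, with the other substituents of compound 3 held fixed, replacing the carbocyclic ring with an open chain carrying a double bond does not separate the two compounds on this read-out. No supporting data bear on why the number stays put.

On these data alone, whether an amine, a carboxylic acid or a longer chain on this carbon would give a step beyond the scatter remains open. Also open, as far as these compounds go, is whether the double bond of but-3-en-1-yl matters, which a saturated butyl chain at the same carbon would address.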